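The compounds below may be only part of what the source reports. "The series", "measured", "known", "first", "only" and "open" are said of these compounds alone.

Measured compounds, with their results in a functional assay on A549 cells (Homo sapiens) for cytotoxicity, read by MTT assay; a lower number here means a stronger inhibitor, a higher number a weaker inhibitor:
- compound 1 `O=c1c(-c2nnc(COc3ccccc3)o2)cn(C2CC2)c2cc(N3CCNCC3)c(F)cc12`: 48.6 ug/mL
- compound 2 `O=c1c(-c2nnc(-c3ccccc3)o2)cn(C2CC2)c2cc(N3CCNCC3)c(F)cc12`: 46 ug/mL

Compound 2 gives the lowest of the two numbers in this assay; the gap to compound 1, a 1.1-fold lower number from compound 1 to compound 2 (0.02 log units; within the scatter), lies within the scatter, so the two values cannot be set in order.

Compound 3 `CCn1cc(-c2nnc(-c3ccccc3)o2)c(=O)c2cc(F)c(N3CCNCC3)cc21` is the next compound. It differs from compound 2 in one place: ethyl in place of cyclopropyl on an aromatic nitrogen.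

Within the data shown here, the only measured step, from phenoxymethyl to phenyl, concerns a different part of the shared core, and it stayed within the scatter. Among the measured compounds shown here, no measured step touches the group on the aromatic nitrogen, so nothing here shows how that change alters the number. The expected step is therefore set as none beyond the scatter, no change at the digits printed from compound 2 to compound 3 (within the scatter), with a wide range to allow for the unknown. For compound 3 the estimated value in this assay is 46 ug/mL, between 18 ug/mL and 110 ug/mL.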

Compound 3, half-maximal inhibitory concentration: 112 ug/mL
Estimate against measurement, compound 3: 2.4-fold (0.39 log units) below; measured number outside the range, above it.
By their numbers in this assay, from the lowest: compounds 2 and 1 (each within the scatter of the next); then compound 3.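

In this assay, the group on the aromatic nitrogen does matter: ethyl in place of cyclopropyl gives a 2.4-fold higher number from compound 2 to compound 3 (0.39 log units; beyond the scatter), a modest step beyond the scatter that leaves the ethyl compound the weaker inhibitor of this pair. Among these compounds, the change from phenoxymethyl to phenyl gave only a 1.1-fold lower number from compound 1 to compound 2 (0.02 log units; within the scatter), within the scatter, so this is the first single change here that clearly moves the number. The swap removes a three-membered ring and one carbon together, and no measurement shown here explains the step or separates those two differences.

On these data alone, whether a propyl chain or a cyclobutyl ring on this nitrogen would give a number closer to compound 2 or to compound 3 remains open. So does whether the same swap would give a similar step with phenoxymethyl in place of phenyl.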